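Phenyl in Place of Isopentyl on the Shared Core

The source may hold more compounds than are shown below. What is called first, only, known or untested is meant among the compounds shown, and "the series" means these compounds.

Measured compounds:
compound 1, `CC(C)CCCOc1cccc(O)c1C(=O)/C=C/c1ccc(O)cc1`: 3520 nM
compound 2, `CCC(CC)COc1cccc(O)c1C(=O)/C=C/c1ccc(O)cc1`: 1960 nM

In a functional assay on NUGC-3 cells (Homo sapiens) for antiproliferative activity, read by sulforhodamine B assay (a lower number here means a stronger inhibitor of growth, a higher number a weaker inhibitor of growth), compound 1 gives 3520 nM, and its only comparator, compound 2, gives 1960 nM; the step of a 1.8-fold lower number from compound 1 to compound 2 (0.25 log units; within the scatter) lies within the scatter, so the two numbers are indistinguishable. Compound 3, `O=C(/C=C/c1ccc(O)cc1)c1c(O)cccc1OCc1ccccc1`, differs from compound 1 by phenyl in place of isopentyl on a saturated chain carbon bound to an oxygen on an aromatic ring. Among the measured compounds shown here, no measured step exchanges a chain for an aromatic ring at this position, and the one step available was small. Compound 3 is therefore expected to show a 1.4-fold lower number from compound 1 to compound 3 (0.15 log units; within the scatter), with the estimate for compound 3 being 2500 nM, plausibly between 700 nM and 9000 nM.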

Compound 3, concentration for 50% growth inhibition: > 30000 nM
Compound 3: a limit, no number (the forecaster's own chance of this, stated with the estimate: 5%); middle value at least 12-fold (1.07 log units) away from the limit.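

In this assay compound 3 gives > 30000 nM, which is a limit of the assay and not a number. Phenyl in place of isopentyl gives an at least 8.5-fold higher number from compound 1 to compound 3 (0.93 log units; beyond the scatter), and phenyl in place of pentan-3-yl gives an at least 15-fold higher number from compound 2 to compound 3 (1.18 log units; beyond the scatter). Among the compounds shown here, the two saturated chains could not be told apart at this position, so the change to an aromatic ring is the first exchange here that moves growth inhibition beyond the scatter, and it weakens it. The compounds shown leave open whether a saturated cyclohexyl ring would behave like the chains or like phenyl. They also leave open how a longer chain or an amine would read here.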